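A few compounds are considered here, and "the series" means these few. Any claim that something is new, unique, unknown or untested is made for them only; others in the source may bear on it.

Compound 2 `CCc1nnc(-c2ccc(-c3ccccc3)cc2)n1-c1cccc(Br)c1C` stands at the high end of the two numbers in hand: in an assay on C6 glioma cells for displacement of a labelled ligand from sodium- and chloride-dependent glycine transporter 1 (Rattus norvegicus), read by scintillation counting, with stated times of 30 min and 10 min (on this read-out lower numbers stand for stronger inhibition and higher numbers for weaker inhibition), compound 2 gives 2200 nM, while compound 1 `CCc1nnc(-c2ccc(-c3ccccc3)cc2)n1-c1cccc(N)c1C` gives 320 nM. Among the compounds with values here, the single measured step that connects them, a 6.9-fold higher number from compound 1 to compound 2 (0.84 log units; beyond the scatter), is the only one that bears on the next change. Compound 3 `CCc1nnc(-c2ccc(-c3ccccc3)cc2)n1-c1cccc(C(N)=O)c1C` differs from compound 2 by carbamoyl in place of bromo on an aromatic carbon. Within the data shown here, no measured pair shows a carbamoyl at this position, so the expectation rests on that one step: replacing amino with bromo at this carbon raised the number, and replacing bromo in turn with a group that carries a hydrogen-bond donor and acceptor is expected to move the number back down, though not necessarily all the way to compound 1. The estimated step is a 3.1-fold lower number from compound 2 to compound 3 (0.50 log units; beyond the scatter). Compound 3 is therefore expected to give about 700 nM in this assay, within a range from 250 nM to 2000 nM.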

Compound 3, half-maximal inhibitory concentration: 3900 nM
Compound 3: the middle estimate sits 5.6-fold (0.75 log units) below what was measured; the measured number lies above the stated range.
By their numbers in this assay, from the lowest: compound 1; then compounds 2 and 3 (each within the scatter of the next).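

In this assay, exchanging bromo for carbamoyl gives a 1.8-fold higher number from compound 2 to compound 3 (0.25 log units; within the scatter), so the two groups cannot be told apart at this position, even though carbamoyl brings a hydrogen-bond donor and acceptor and bromo brings neither. Set against the amino group, the same carbamoyl gives a 12-fold higher number from compound 1 to compound 3 (1.09 log units; beyond the scatter), so among the three groups shown, amino alone stands apart from the other two, and the donor and acceptor counted for carbamoyl do not by themselves bring the number back to that of compound 1. Nothing available explains why these groups differ as they do.

The compounds shown leave open whether the lower number belongs to the amino group alone or extends to relatives such as methylamino, aminomethyl or hydroxyl at this carbon. They also leave open how a carboxylic acid would behave there.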